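Aryl swap on the series: compound 1 to compound 4

The source may report more compounds than this note shows. Statements on the series, on what has been measured and on what is new or still open speak of the compounds shown alone.

Among the measured compounds shown here, in a functional assay on U-373MG ATCC cells (Homo sapiens) for inhibition, read by MTT assay, with a stated time of 72 h (a lower number here means a stronger inhibitor, a higher number a weaker inhibitor), compound 1 (`COc1ccc(NC(=S)NC2CC(C)(C)Oc3ccc(Br)cc32)cc1`) gives 40000 nM as the highest of the three numbers measured so far. Compound 2 (`CC1(C)CC(NC(=O)Nc2ccccc2Cl)c2cc(Cl)ccc2O1`) gives 17000 nM and compound 3 (`CC1(C)CC(NC(=S)Nc2ccc([N+](=O)[O-])cc2)c2cc(Br)ccc2O1`) gives 9000 nM in the same read-out.

Compound 4 (`CC1(C)CC(NC(=S)Nc2cccc(Cl)c2)c2cc(Br)ccc2O1`) has not yet been measured. Its difference from compound 1 is 3-chlorophenyl in place of 4-methoxyphenyl on an amide-type nitrogen and amounts to 3-chlorophenyl in place of 4-methoxyphenyl on an amide-type nitrogen, whose other neighbour is the thiocarbonyl carbon.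

For the measured compounds named here, one measured step bears on this change: a 4.4-fold lower number from compound 1 to compound 3 (0.65 log units; beyond the scatter) is modest but beyond the scatter. Going by the values given here, that step also replaces the methoxy group, but with nitro, and no measured compound carries the 3-chlorophenyl group. Among the compounds with values here, compound 2 differs from compound 1 in more than one place, so it offers no clean step. This single step is thin support, so a lower number is expected for the new compound, though by less than the measured step. The estimated change is a 2.5-fold lower number from compound 1 to compound 4 (0.40 log units; beyond the scatter) and would still need confirming. For compound 4 the estimated value is 16000 nM with an expected range from 6000 nM to 38000 nM in this assay for now.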

Compound 4, half-maximal inhibitory concentration: 8000 nM
For compound 4 the middle estimate is 2.0-fold (0.30 log units) above the measured one, within the range that was stated.
By their numbers in this assay, from the lowest: compounds 4, 3 and 2 (each within the scatter of the next, the first and the last beyond it); then compound 1.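

Among the compounds shown here, on the amide-type nitrogen whose other neighbour is the thiocarbonyl carbon, 3-chlorophenyl in place of 4-methoxyphenyl gives a 5.0-fold lower number from compound 1 to compound 4 (0.70 log units; beyond the scatter) in this assay, so the earlier step with nitro in place of methoxy, a 4.4-fold lower number from compound 1 to compound 3 (0.65 log units; beyond the scatter), no longer stands alone as the only clean change at this aryl group to lower the number. Compound 3 at 9000 nM and compound 4 at 8000 nM lie within the scatter of each other, which means that two quite different aryl groups on the same core cannot be ranked in this read-out, while both stand clear of the 4-methoxyphenyl group of compound 1. Nothing measured here explains why these replacements lower the number, and the steps give only the size of the change.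

Compound 4 changes both the substituent and its printed ring position relative to compound 1, so the compounds shown do not separate the effect of chlorine from that of its placement. Whether the number depends on the groups shown at all stays open, as an unsubstituted phenyl ring, an amine or a carboxylic acid on that ring lies outside the compounds shown.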